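A Methoxy Group on the Phenylsulfanyl Compound

The source may report more compounds than this note shows. Statements on the series, on what has been measured and on what is new or still open speak of the compounds shown alone.

In a functional assay on JC cells (Mus musculus) for inhibition, read by sulforhodamine B assay, with a stated time of 48 h (on this read-out lower numbers stand for stronger inhibition and higher numbers for weaker inhibition), compound 1 (`COc1cccc(Cn2cc(CCc3cc(OC)c(OC)c(OC)c3)c3c(C)nc(N)nc32)c1`) gives 1400 nM and compound 2 (`COc1ccc(Cn2cc(CCc3cc(OC)c(OC)c(OC)c3)c3c(C)nc(N)nc32)cc1`) gives 600 nM. Compound 3 (`Cc1nc(N)nc2c1c(Sc1ccccc1)cn2Cc1ccccc1`) has the highest number of the three at 4000 nM, beyond the scatter from both of the others. Compound 4 (`COc1ccc(Sc2cn(Cc3ccccc3)c3nc(N)nc(C)c23)cc1`) differs from it by methoxy in place of hydrogen on an aromatic carbon, which turns phenylsulfanyl into (4-methoxyphenyl)sulfanyl: methoxy in place of hydrogen on an aromatic carbon.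

Among the measured compounds shown here, no measured pair shows a methoxy replacing hydrogen. The nearest evidence is a 2.3-fold lower number from compound 1 to compound 2 (0.37 log units; beyond the scatter), a modest step in which 4-methoxyphenyl takes the place of 3-methoxyphenyl on a saturated chain carbon bound to an aromatic nitrogen. That step bears on the change only indirectly, since it moves a methoxy rather than adding one, and it sits elsewhere on the molecule. On this thin evidence, a modest step of similar size toward a lower number is expected, a 2.2-fold lower number from compound 3 to compound 4 (0.35 log units; beyond the scatter). The estimate for compound 4 is 1800 nM, with an expected range of 600 nM to 5000 nM.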

Compound 4, half-maximal inhibitory concentration: 10000 nM
Estimate against measurement, compound 4: 5.6-fold (0.74 log units) below; the whole stated range lies below it.
By their numbers in this assay, from the lowest: compound 2; then compound 1; then compound 3; then compound 4.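

Methoxy in place of hydrogen on an aromatic carbon of the phenylsulfanyl group gives, in this assay, a 2.5-fold higher number from compound 3 to compound 4 (0.40 log units; beyond the scatter), which stands for weaker inhibition. Among the compounds shown here, this is the only direct reading of a methoxy added rather than moved, and it shows that at this place, para to a large group, the addition goes toward weaker inhibition. The earlier step between compound 1 and compound 2 moved a methoxy on a different part of the molecule, and its direction does not carry over here. No measurement shown accounts for the direction of this step.

The compounds shown compare only hydrogen and methoxy at this carbon, so it stays open whether the shift belongs to methoxy itself or to any group placed there. A chloro or a hydroxy group at the same place could tell these apart.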